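Ester replacing hydrogen on a piperazine-like sulfonamide core

The source may report more compounds than this note shows. Statements on the series, on what has been measured and on what is new or still open speak of the compounds shown alone.

Compound 1 `CC(=O)N1CCN(S(=O)(=O)c2ccc(F)cc2)CC1` is the starting point of this comparison. In a physicochemical assay for metabolic stability, read by LC-MS, in phosphate buffer, tested at 1 uM (on this read-out lower numbers stand for a shorter-lived compound and higher numbers for a longer-lived compound), compound 1 gives only a limit of the assay, >= 4 h, not a number. Compound 2 `CC(=O)N1CCN(S(=O)(=O)c2ccc(F)cc2)CC1CO` carries a hydroxymethyl group on the saturated ring; in this assay compound 2 also reaches only the limit, >= 4 h. Compound 3 `CC(=O)OCC1CN(S(=O)(=O)c2ccc(F)cc2)CCN1C(C)=O` carries an acetoxymethyl group instead; in this assay compound 3 likewise stops at the limit, >= 4 h. The steps between these three are therefore not readable: a step that the two limits leave unreadable from compound 1 to compound 2, a step that the two limits leave unreadable from compound 1 to compound 3 and a step that the two limits leave unreadable from compound 2 to compound 3. What they share is the limit of >= 4 h in this assay, at which 3 of the 3 values shown sit.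

Compound 4 `CCOC(=O)C1CN(C(C)=O)CCN1S(=O)(=O)c1ccc(F)cc1` differs from compound 1 by ethoxycarbonyl in place of hydrogen on a saturated ring carbon. Among the compounds with values here, none of the measured steps shows a drop once a group is placed on that saturated ring carbon, whether hydroxymethyl or acetoxymethyl, so the closest parallel is that every measured compound sits at the same limit. The expectation for compound 4 is accordingly a step of about a number no higher from compound 1 to compound 4 (the limit leaves the size open), which means none beyond the scatter. In this assay compound 4 is therefore estimated at 4 h, within a range from 2 h to 8 h, most likely again reported only as the limit.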

Compound 4, half-life: >= 4 h
Compound 4 ended at the assay's limit; the forecaster's own chance of this, stated with the estimate: 80%; the middle value sits exactly at the limit.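

Compound 4, like compound 1, gives only a limit and not a number in this assay, so no new step can be read from this result: the limit of >= 4 h in this assay, at which 4 of the 4 values shown sit. The compounds shown leave open how long each one really lasts in this assay, and whether any group placed on the saturated ring carbon changes that half-life at all.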